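Swapping the aryl ring of a trimethoxychalcone

The source may report more compounds than this note shows. Statements on the series, on what has been measured and on what is new or still open speak of the compounds shown alone.

Measured compounds:
- compound 1 `COc1cccc(/C=C/C(=O)c2c(OC)cc(OC)cc2OC)c1`: 0.3%
- compound 2 `COc1cc(O)c(C(=O)/C=C/c2ccccc2OC)c(OC)c1`: "not active" (no number reported)

Among the measured compounds shown here, in a functional assay on Huh-7 cells (Homo sapiens), read by fluorescence and BrdU incorporation, with a stated time of 48 h, tested at 25 uM (a lower number here means a stronger effect, a higher number a weaker effect of the compound at the concentration tested), compound 1 gives 0.3%, the only number reported in this set. Compound 2 is reported in this assay only as "not active" (no number reported), so the two cannot be compared beyond that. Compound 3 `COc1cc(OC)c(C(=O)/C=C/c2ccc(Cl)cc2)c(OC)c1` differs from compound 1 in one place: 4-chlorophenyl in place of 3-methoxyphenyl on a double-bonded chain carbon bound to a double-bonded chain carbon. For the measured compounds named here, whether a change at that position shifts the read-out cannot be judged from the measured pair, since no step between numbered compounds is available. Because compound 1 already gives 0.3%, little room remains for a stronger effect, so any step is expected to go toward a weaker effect or to stay within the scatter; the expected step of a number 7.7 percentage points higher from compound 1 to compound 3 (within the scatter) is small. Compound 3 is therefore estimated at 8% in this assay, within a range from 0% to 35%.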

Compound 3, a percentage reported as activity, at one concentration (the size of the read-out at that concentration, not a potency): 0.8%
Compound 3: middle estimate off by 7.2 percentage points, on the high side, within the range that was stated.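

In this assay, among the compounds shown here, putting 4-chlorophenyl in place of 3-methoxyphenyl on a double-bonded chain carbon bound to a double-bonded chain carbon gives a number 0.5 percentage points higher from compound 1 to compound 3 (within the scatter) and so provides the first readable step at this position. The read-out therefore does not separate compound 1 from compound 3, even though the group that leaves carries oxygen and a hydrogen-bond acceptor while the group that enters carries chlorine and no acceptor. No measurement shown here explains why these two groups read alike.

With only one concentration, this result says nothing about whether the two compounds differ in potency. Also open, from the compounds shown here alone, is whether the same position would give a similar read-out with an amine or a carboxylic acid on the ring, or with a longer chain in place of the ring.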